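From a methoxy limit to a chlorinated aryl group

The source may hold more compounds than are shown below. What is called first, only, known or untested is meant among the compounds shown, and "the series" means these compounds.

Measured in a functional assay on PC-3 cells (Homo sapiens) for cytotoxicity, read by MTT assay, with a stated time of 72 h; a lower number here means a stronger inhibitor, a higher number a weaker inhibitor:
- compound 1 `O=C(Nc1ccc(Oc2ccnc3[nH]ccc23)cc1)c1nn(-c2ccc(Cl)cc2)ccc1=O`: 32400 nM
- compound 2 `COc1ccc(-n2ccc(=O)c(C(=O)Nc3ccc(Oc4ccnc5[nH]ccc45)cc3)n2)cc1`: > 60000 nM (a limit of the assay, not a number)

In this assay compound 2 has only a limit and no true number, and it sits at the limit of > 60000 nM in this assay, at which 1 of the 2 values shown sits.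

The next compound, compound 3 `O=C(Nc1ccc(Oc2ccnc3[nH]ccc23)cc1)c1nn(-c2ccc(Cl)c(C(F)(F)F)c2)ccc1=O`, differs from compound 2 in one group: 4-chloro-3-(trifluoromethyl)phenyl in place of 4-methoxyphenyl on an aromatic nitrogen. Here 4-chloro-3-(trifluoromethyl)phenyl replaces 4-methoxyphenyl on an aromatic nitrogen.

Within the data shown here, one measured step bears on this change: an at least 1.8-fold higher number from compound 1 to compound 2 (0.26 log units; that floor lies within the scatter). Its floor lies within the scatter, so it gives only weak guidance on swapping chloro and methoxy. Compound 3 shares a chloro group with compound 1 , and compound 1 gives 32400 nM, so a value in that region is expected. Among the measured compounds shown here, no measured compound shows what the added trifluoromethyl does, and compound 3 could also end up at the limit.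

The expected change is an at least 2.1-fold lower number from compound 2 to compound 3 (0.33 log units; beyond the scatter), a modest move towards a lower number. For compound 3 the estimated value is 28000 nM, with an expected range of 10000 nM to 60000 nM.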

Compound 3, half-maximal inhibitory concentration: 4630 nM
Compound 3: middle estimate off by 6.0-fold (0.78 log units), on the high side, outside the stated range (below it).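

On the aryl group carried by the aromatic nitrogen, this assay now shows a change that clearly moves the number: trifluoromethyl in place of hydrogen on an aromatic carbon gives a 7.0-fold lower number from compound 1 to compound 3 (0.84 log units; beyond the scatter). The earlier pair showed only a floor within the scatter, whereas exchanging 4-methoxyphenyl for 4-chloro-3-(trifluoromethyl)phenyl gives an at least 12-fold lower number from compound 2 to compound 3 (1.11 log units; beyond the scatter), so the choice of aryl group at this position can matter a great deal. That second step is a floor and not an exact size, since compound 2 stands at a limit of the assay and not at a number: the limit of > 60000 nM in this assay, at which 1 of the 3 values shown sits.

On these data alone, it remains open whether trifluoromethyl would give the same gain without the chloro group, and whether a nitrile or an amine in its place would match it. The compounds shown also leave open whether a different group on this ring, such as a carboxylic acid or a longer alkyl chain, would push the number lower still or back towards that of compound 1.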